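The compounds below may be only part of what the source reports. "The series", "measured", "known", "first", "only" and "open" are said of these compounds alone.

Measured compounds in a functional assay on A549 cells (Homo sapiens) for antiproliferative activity, read by MTT assay, with a stated time of 72 h; on this read-out higher numbers stand for weaker inhibition and lower numbers for stronger inhibition:

compound 1 `COc1cccc(N2C(=O)COc3ccc(-c4cnc(Cl)c(NS(=O)(=O)c5ccc(F)cc5)c4)cc32)c1`: 32700 nM
compound 2 `O=C1COc2ccc(-c3cnc(Cl)c(NS(=O)(=O)c4ccc(F)cc4)c3)cc2N1C1CCCCC1`: 37900 nM
compound 3 `COc1cccc(N2C(=O)COc3ccc(-c4cnc5ccccc5c4)cc32)c1`: > 40000 nM, which is a limit of this assay and not a number

Compound 1 and compound 2 share one core and differ only at the amide-type nitrogen in the ring: cyclohexyl in place of 3-methoxyphenyl on an amide-type nitrogen in a ring. That exchange gives a 1.2-fold higher number from compound 1 to compound 2 (0.06 log units; within the scatter), so the two values are not told apart by this assay.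

Compound 3 carries a different core; the difference between the two cores is not broken down here. Compound 3 sits at the limit of > 40000 nM in this assay, at which 1 of the 3 values shown sits, so for it this assay gives only a limit.

Compound 4 `O=C1COc2ccc(-c3cnc4ccccc4c3)cc2N1C1CCCCC1` is not yet measured. It stands to compound 3 as compound 2 stands to compound 1: cyclohexyl in place of 3-methoxyphenyl on an amide-type nitrogen in a ring. The place line reads the same for both pairs, so this is the same kind of change on a different core. Going by the values given here, the only measured instance of it, from compound 1 to compound 2, stayed within the scatter. On that basis the step from compound 3 to compound 4 is expected to be small as well, estimated at a step that the limit leaves unreadable from compound 3 to compound 4. Since compound 3 itself gives only a limit, compound 4 is expected to stay in the same region and quite possibly to be reported only as a limit again. The estimate for compound 4 in this assay is 45000 nM, with an expected range from 28000 nM to 90000 nM.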

Compound 4, half-maximal inhibitory concentration: > 40000 nM
Compound 4: a limit, no number; the forecaster's own chance of this, stated with the estimate: 70%; the middle value lies beyond the limit too.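

In this assay compound 4 gives > 40000 nM, a limit and not a number. Compound 3 is also held at a limit, > 40000 nM, so no step between compound 3 and compound 4 can be read: the limit of > 40000 nM in this assay, at which 2 of the 4 values shown sit.

The compounds shown leave open whether cyclohexyl in place of 3-methoxyphenyl on an amide-type nitrogen in a ring acts on the core of compound 3 as it does on the core of compound 1.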